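The source may hold more compounds than are shown below. What is called first, only, known or untested is meant among the compounds shown, and "the series" means these compounds.

Measured so far in a functional assay on MCF7 cells (Homo sapiens) for cytotoxicity; a higher number here means a weaker inhibitor of growth, a lower number a stronger inhibitor of growth:
compound 1 `C/C(=C/CC/C(C)=C/CC/C(C)=C/C(=O)C/C(C)=C/Cc1cc(O)cc(C)c1O)CO` — 2.2 ug/mL
compound 2 `C/C(=C/CC/C(C)=C/CC/C(C)=C\C(=O)C/C(C)=C/Cc1cc(O)cc(C)c1O)CO` — 1.8 ug/mL

Compound 1 carries the highest of the two numbers; its nearest neighbour is compound 2, with a 1.2-fold lower number from compound 1 to compound 2 (0.09 log units; within the scatter), a step that rests on the fact that compounds 1 and 2 differ only in the configuration as drawn alone. The unmeasured compound 3 `C/C(=C\C(=O)C/C(C)=C/Cc1cc(O)cc(C)c1O)CC/C=C(\C)Cc1cc(C)co1` is reached from compound 1 by 4-methylfuran-2-yl in place of 3-(hydroxymethyl)but-2-en-1-yl on a saturated chain carbon bound to a double-bonded chain carbon. Within the data shown here, no measured step touches this part of the chain: the only step known, from compound 1 to compound 2, changes nothing but the drawn configuration of one double bond and stays within the scatter, so it offers no guide to the size or direction of the new change. The expectation for compound 3 is therefore kept close to compound 1, with a wide range to cover the lack of comparable steps. The step expected is a 1.1-fold higher number from compound 1 to compound 3 (0.06 log units; within the scatter). In this assay compound 3 is estimated at 2.5 ug/mL, between 0.7 ug/mL and 9 ug/mL.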

Compound 3, concentration for 50% growth inhibition: 1.3 ug/mL
Compound 3: the middle estimate sits 1.9-fold (0.28 log units) above what was measured, and the stated range covers the measured number.
By their numbers in this assay, from the lowest: compounds 3, 2 and 1 (each within the scatter of the next).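

Among these compounds, exchanging 3-(hydroxymethyl)but-2-en-1-yl for 4-methylfuran-2-yl on a saturated chain carbon bound to a double-bonded chain carbon gives in this assay a 1.7-fold lower number from compound 1 to compound 3 (0.23 log units; within the scatter) and is the first change that alters the atoms and bonds. The position therefore accepts an open chain with a double bond being replaced by a five-membered aromatic ring, with 1 hydrogen-bond donor going to 0 hydrogen-bond donors, without a step beyond the scatter. Nothing measured on these compounds gives a reason for this step.

This single exchange cannot separate the loss of the hydroxymethyl from the arrival of the ring. As far as these compounds go, whether a carboxylic acid or an amine in place of the hydroxymethyl, or a longer chain carrying the 4-methylfuran-2-yl, would stay in the same range remains open.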